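The compounds below may be only part of what the source reports. "The series", "measured", "known", "first", "only" and "open" are said of these compounds alone.

Working notes on the series. Among the measured compounds shown here, compound 1 `c1ccc(COc2ccc(OCCOCCNc3cc[nH]c3)cc2)cc1` gives 11300 nM in a functional assay on SK-OV-3 cells (Homo sapiens) for inhibition, read by CCK-8 assay, with a stated time of 70 h (on this read-out higher numbers stand for weaker inhibition and lower numbers for stronger inhibition), the lowest of the three numbers so far but within the scatter of both neighbours. Compound 3 `Nc1ccccc1COc1ccc(OCCOCCNC2CCCC2)cc1` gives 14000 nM in this assay, and compound 2 `O=[N+]([O-])c1ccc(COc2ccc(OCCOCCNC3CCCC3)cc2)cc1` gives 20300 nM. For the measured compounds named here, the only step measured in one place, a 1.5-fold lower number from compound 2 to compound 3 (0.16 log units; within the scatter), concerns the group on the saturated chain carbon bound to an oxygen on an aromatic ring, not the amine end, and stays within the scatter.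

Compound 4 `c1ccc(COc2ccc(OCCOCCNC3CCC3)cc2)cc1` differs from compound 1 at the amine nitrogen: cyclobutyl in place of 1H-pyrrol-3-yl on an amine nitrogen. Going by the values given here, no measured step touches this position directly. Among the compounds with values here, compounds 2 and 3 carry a cyclopentylamino group at the same place and sit within the scatter of compound 1, which speaks for a small ring on the amine nitrogen giving numbers in the same region; with only three compounds, no firmer pattern can be drawn. For compound 4 a change a 1.2-fold higher number from compound 1 to compound 4 (0.06 log units; within the scatter) is therefore expected, nothing beyond the scatter. Compound 4 is estimated at 13000 nM, with a range from 5000 nM to 35000 nM.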

Compound 4, half-maximal inhibitory concentration: 25000 nM
The estimate for compound 4 lay 1.9-fold (0.28 log units) below the measured number, within the range that was stated.
By their numbers in this assay, from the lowest: compounds 1, 3, 2 and 4 (each within the scatter of the next, the first and the last beyond it).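

Among the compounds shown here, this is the first step measured at the amine nitrogen, and in this assay cyclobutyl in place of 1H-pyrrol-3-yl gives a 2.2-fold higher number from compound 1 to compound 4 (0.34 log units; beyond the scatter) as the only step so far beyond the scatter. The position therefore does respond to the group it carries, though modestly, and a small ring there does not by itself guarantee a number like that of compound 1. The change removes an aromatic ring and a hydrogen-bond donor together, and this single pair cannot separate the two; nothing measured on these compounds explains the difference.

Open, from the compounds shown here alone, is whether phenyl, which has an aromatic ring but no hydrogen-bond donor, would read with compound 1 or with compound 4. Also open, going by these compounds, is how 1H-imidazol-4-yl or an open-chain isopropyl would behave on the same amine nitrogen.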